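Changing the benzyl halogens on a compound tolerated at the limit

The source may report more compounds than this note shows. Statements on the series, on what has been measured and on what is new or still open speak of the compounds shown alone.

Compound 1 `Cn1cc(SCc2nnc(S)n2-c2c(Cl)cccc2Cl)c2ccccc21` in a toxicity assay on HEK-293T cells (Homo sapiens) for cytotoxicity, read by CCK-8 assay, with a stated time of 48 h (a lower number here means that less compound is tolerated, a higher number that more compound is tolerated), gives > 100000 nM.
Compound 2 `Cn1cc(SCc2nnc(SCc3ccc(Cl)cc3Cl)n2-c2c(Cl)cccc2Cl)c2ccccc21` in this assay gives > 100000 nM.

For compound 1 the value is a limit of the assay, not a number. For compound 2 the value is likewise a limit of the assay. Compound 2 therefore stands at the limit, with no readable number of its own, and the step that the two limits leave unreadable from compound 1 to compound 2 cannot be sized; all that is known is the limit of > 100000 nM in this assay, at which 2 of the 2 values shown sit.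

Compound 3 `Cn1cc(SCc2nnc(SCc3cccc(Cl)c3F)n2-c2c(Cl)cccc2Cl)c2ccccc21` differs from compound 2 by 3-chloro-2-fluorophenyl in place of 2,4-dichlorophenyl on a saturated chain carbon bound to a sulfur. For the measured compounds named here, no measured step bears readably on this change, since the only step available is unreadable. Given (the limit of > 100000 nM in this assay, at which 2 of the 2 values shown sit), compound 3 is expected to sit at the same limit, so the expected step that the limit leaves unreadable from compound 2 to compound 3 is none beyond the scatter. The estimate for compound 3 in this assay is 150000 nM, ranging from 50000 nM to 500000 nM.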

Compound 3, half-maximal cytotoxic concentration: > 100000 nM
Compound 3: a limit, no number; the forecaster's own chance of this, stated with the estimate: 80%; the middle value does not contradict the limit.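

In this assay compound 3 gives > 100000 nM, which is a limit and not a number. No step among compound 1, compound 2 and compound 3 can be read: the limit of > 100000 nM in this assay, at which 3 of the 3 values shown sit.

As far as these compounds go, what stays open is the concentration at which any of these three compounds stops being tolerated, and whether changing the benzyl halogens alters it.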